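Benzyl in place of cyclohexyl on an aminopyrimidine

A few compounds are considered here, and "the series" means these few. Any claim that something is new, unique, unknown or untested is made for them only; others in the source may bear on it.

The series shares a core in which a diamine chain carries an amide at one end and a second amine sits on the ring. Compound 1 `O=C(NCCCNc1nc(Nc2cccnc2)ncc1C1CC1)C1CCC1` and compound 3 `CN1CCC(c2ccc(Nc3ncc(C4CC4)c(NCCCNC(=O)C4CCC4)n3)cc2)CC1` both bear an aromatic amine on that ring and a cyclobutyl amide. In an assay on isolated protein for inhibition of serine/threonine-protein kinase TBK1 (Homo sapiens) (on this read-out higher numbers stand for weaker inhibition and lower numbers for stronger inhibition), compound 1 gives 13 nM. In this assay compound 3 gives 8 nM, and the two values lie within the usual scatter of each other.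

Compound 2 `O=C(NCCCNc1nc(NC2CCCCC2)ncc1C1CC1)c1cccs1` carries a cyclohexyl group on the ring nitrogen and a thiophene amide. In this assay compound 2 is reported only as a limit, > 10000 nM, so its true value is not known. It stands at the limit of > 10000 nM in this assay, at which 1 of the 3 values shown sits, the weak end of what has been measured so far.

Compound 4 `O=C(NCCCNc1nc(NCc2ccc(F)cc2)ncc1C1CC1)c1cccs1` keeps the thiophene amide and differs from compound 2 in one place: 4-fluorobenzyl in place of cyclohexyl on a nitrogen on an aromatic ring. Whether this alone restores the inhibition seen with the aromatic amines of compound 1 and compound 3 is open. He expects a gain of moderate size, from compound 2 to compound 4 an at least 2.0-fold lower number from compound 2 to compound 4 (0.30 log units; that floor lies within the scatter), but not one reaching the values of compound 1 or compound 3. Compound 4 is therefore estimated at 5000 nM, within 800 nM to 30000 nM.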

Compound 4, half-maximal inhibitory concentration: > 10000 nM
Compound 4: no number, only a limit; the forecaster's own chance of this, stated with the estimate: 45%; middle value at least 2.0-fold (0.30 log units) from the limit.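

In this assay compound 4 is reported only as a limit, > 10000 nM. Compound 2 also stands only as a limit, so no step between the two can be read: the limit of > 10000 nM in this assay, at which 2 of the 4 values shown sit.

The compounds shown leave open whether 4-fluorobenzyl in place of cyclohexyl changes the inhibition at all, and how far the true values of compound 2 and compound 4 lie from that limit.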